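Diarylidene piperazinedione series: aryl swap on the allyl-substituted core

The source may hold more compounds than are shown below. What is called first, only, known or untested is meant among the compounds shown, and "the series" means these compounds.

Measured so far in a functional assay on K562 cells (Homo sapiens) for cytotoxicity, read by CCK-8 assay, with a stated time of 72 h; a lower number here means a stronger inhibitor, a higher number a weaker inhibitor:
- compound 1, `COc1ccccc1/C=c1/[nH]c(=O)/c(=C\c2ccccc2OC)[nH]c1=O`: "not active" (no number reported)
- compound 2, `COc1ccccc1/C=c1\c(=O)[nH]/c(=C/c2ccccc2Cl)c(=O)n1C`: 110 nM
- compound 3, `C=CCn1c(=O)/c(=C\c2ccc(F)c(Br)c2)[nH]c(=O)/c1=C\c1ccccc1OC`: "not active" (no number reported)

Only compound 2 has a number in this assay; for compound 1 and compound 3 no single value is reported, both being recorded as "not active" (no number reported). Compound 3 therefore stands at the bottom of what is known, with one further entry, compound 1, in the same position. Nothing in the set relates compound 2 to compound 3 by a single change, so compound 2 serves only as a reminder that the shared core can reach a measurable number.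

Compound 4, `C=CCn1c(=O)/c(=C\c2ccc(C)cc2)[nH]c(=O)/c1=C\c1ccccc1OC`, is obtained from compound 3 by the change (4-methylphenyl in place of 3-bromo-4-fluorophenyl on a double-bonded chain carbon bound to an aromatic carbon). Going by the values given here, no step between measured compounds is known for this kind of change, and compound 3 itself gives no number from which to step. The expectation is that compound 4 stays weak in this assay, most likely near the point where no number is returned, with any shift from compound 3 not demonstrably beyond the scatter. Compound 4 is estimated at 8000 nM, within a range of 1500 nM to 50000 nM.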

Compound 4, half-maximal inhibitory concentration: "not active" (no number reported)
Compound 4: no number reported; the estimate stays without a comparison.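

Compound 3 and compound 4 both lack a number, so no step can be read from the change of 3-bromo-4-fluorophenyl to 4-methylphenyl. The compounds shown leave open whether this aryl swap shifts cytotoxicity at all, and which single changes separate these two from the measurable compound 2. No supporting evidence bears on this result.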